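The source may hold more compounds than are shown below. What is called first, only, known or untested is meant among the compounds shown, and "the series" means these compounds.

Compound 1 `CC(C)(C)OC(=O)CCCC[N+]1(C)CCc2c(sc(NC(=O)Nc3ccc(Cl)cc3)c2C(N)=O)C1`: 140 nM
Compound 2 `CCN1CCc2c(sc(NC(=O)NCC3CCCO3)c2C(N)=O)C1`: > 25000 nM, a limit of the assay and not a number
Compound 3 `CN1CCc2c(sc(NC(=O)Nc3ccc(Cl)cc3)c2C(N)=O)C1`: 4700 nM

All three compounds were tested in a functional assay (strain AB) with Danio rerio as the target, read by microscopy, with a stated time of 1 h; on this read-out lower numbers stand for an effect already at smaller amounts and higher numbers for an effect only at larger amounts of compound. Of the two results that are actual numbers, the higher belongs to compound 3, at 4700 nM. The lower belongs to compound 1, at 140 nM, and the gap between them lies beyond the usual scatter.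

Compound 4 `CC(C)(C)OC(=O)N1CCc2c(sc(NC(=O)Nc3ccc(Cl)cc3)c2C(N)=O)C1` has tert-butoxycarbonyl in place of methyl on an amine nitrogen in a ring of compound 3: tert-butoxycarbonyl in place of methyl on an amine nitrogen in a ring. Among the compounds with values here, no two measured compounds differ in one place only, so no direct precedent exists for this change. The nearest clue, with a larger group on that nitrogen than compound 3, is compound 1, which gives 140 nM. The comparison is loose, since compound 1 carries a net charge and compound 4 does not. The estimated change is a 2.4-fold lower number from compound 3 to compound 4 (0.37 log units; beyond the scatter), an expected moderate step towards a lower number. For compound 4 the estimated value is 2000 nM, with an expected range of 400 nM to 12000 nM.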

Compound 4, half-maximal effective concentration: > 25000 nM
Compound 4 gave a limit, no number (the forecaster's own chance of this, stated with the estimate: 15%); middle value at least 12-fold (1.09 log units) away from the limit.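

In this assay, putting tert-butoxycarbonyl in place of methyl on the amine nitrogen in the ring gives an at least 5.3-fold higher number from compound 3 to compound 4 (0.72 log units; beyond the scatter). Within the data shown here, this is the first direct reading of a single change at this nitrogen, and it shows that such a change alone can move the result well beyond the usual scatter, towards a higher number. The value of compound 4 is a limit of the assay and not a number, so the full size of the step stays unknown because the reading stops there: the limit of > 25000 nM in this assay, at which 2 of the 4 values shown sit.

On these data alone, it remains open which part of the new group goes with the higher number. An acetyl group on this nitrogen would keep a carbonyl without the tert-butyl part, while a benzyl group would bring a larger group without a carbonyl.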